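Notes on two measured compounds and a third analogue

A few compounds are considered here, and "the series" means these few. Any claim that something is new, unique, unknown or untested is made for them only; others in the source may bear on it.

Measured so far:
compound 1 `COc1cc(OC)c(C(=O)/C=C/c2ccccc2SC)c(OC)c1` — 36%
compound 2 `COc1cc(O)c(C(=O)/C=C/c2ccccc2OC)c(OC)c1` — 46%

In a functional assay on Caco-2 cells (Homo sapiens), read by fluorescence and BrdU incorporation, with a stated time of 48 h, tested at 10 uM (on this read-out higher numbers stand for a weaker effect at the one concentration tested and lower numbers for a stronger effect), compound 1 gives 36% and compound 2 gives 46%. Of the two numbers, compound 2 has the larger read-out, but its distance from compound 1 lies within the scatter, so the two are not separated. Compound 3 `COc1cc(O)c(C(=O)/C=C/c2ccccc2SC)c(OC)c1` differs from compound 2 in one place: methylsulfanyl in place of methoxy on an aromatic carbon. Among the measured compounds shown here, no step between measured compounds covers this change. Compound 1, which already carries methylsulfanyl, gives 36%, so the step of a number 6 percentage points lower from compound 2 to compound 3 (within the scatter) is expected to stay within the scatter. For compound 3 the estimate is 40%, with a range from 25% to 55%.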

Compound 3, a percentage reported as activity, at one concentration (the size of the read-out at that concentration, not a potency): 50%
The estimate for compound 3 lay 10 percentage points below the measured number, within the range that was stated.
By their numbers in this assay, from the lowest: compounds 1, 2 and 3 (each within the scatter of the next, the first and the last beyond it).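

In this assay the exchange of methoxy for methylsulfanyl on an aromatic carbon, ortho to a large group, gives a number 4 percentage points higher from compound 2 to compound 3 (within the scatter) and so does not separate the two compounds. Among the compounds shown here, the one step beyond the scatter here is a different change, hydrogen in place of methyl on an oxygen on an aromatic ring, which gives a number 14 percentage points higher from compound 1 to compound 3 (beyond the scatter) with methylsulfanyl held constant. No measurement offers a cause for either step.

Open, from the compounds shown here alone, is whether an amine or a longer chain such as ethylsulfanyl at this aromatic carbon would move the read-out beyond the scatter.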